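Benzothiazole in Place of Thiazole on the Amide Nitrogen

The source may report more compounds than this note shows. Statements on the series, on what has been measured and on what is new or still open speak of the compounds shown alone.

Compound 2 `O=C(CNC(=O)c1nn(-c2ccccc2)c(=O)c2ccccc12)Nc1nccs1` and compound 1 `CCOC(=O)c1ccc2nc(NC(=O)CNC(=O)c3nn(-c4ccccc4)c(=O)c4ccccc34)sc2c1` share a core in which a carbonyl-linked chain ends in an amide nitrogen bearing a heteroaromatic ring. In an assay on L cells for inhibition of Protein-serine O-palmitoleoyltransferase porcupine (Mus musculus), read by reporter gene assay, with a stated time of 24 h (on this read-out higher numbers stand for an effect only at larger amounts of compound and lower numbers for an effect already at smaller amounts), compound 2 gives only a limit of > 25000 nM and no number. In this assay compound 1 likewise gives only a limit of > 25000 nM. Going by the values given here, both values sit at the limit of > 25000 nM in this assay, at which 2 of the 2 values shown sit, so compound 2 stands at that limit together with the one other measured compound, and no measured step can be compared. Compound 3 `O=C(CNC(=O)c1nn(-c2ccccc2)c(=O)c2ccccc12)Nc1nc2ccccc2s1` differs from compound 2 by 1,3-benzothiazol-2-yl in place of 1,3-thiazol-2-yl on an amide-type nitrogen. With both measured compounds at the limit, no direction can be read, and the expected step that the limit leaves unreadable from compound 2 to compound 3 is none beyond the scatter. Compound 3 is therefore estimated at 30000 nM, within a range from 8000 nM to 100000 nM, with a further limit the most likely outcome.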

Compound 3, half-maximal effective concentration: 2600 nM
The estimate for compound 3 lay 12-fold (1.06 log units) above the measured number; measured number below the stated range.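

In this assay, the amide-type nitrogen is where a change first gives a real number: 1,3-benzothiazol-2-yl, with its added six-membered aromatic ring of carbon only, in place of 1,3-thiazol-2-yl brings an at least 9.6-fold lower number from compound 2 to compound 3 (0.98 log units; beyond the scatter). The larger group alone is not enough, since hydrogen in place of ethoxycarbonyl on an aromatic carbon of that group brings an at least 9.6-fold lower number from compound 1 to compound 3 (0.98 log units; beyond the scatter). Each step is only a minimum, because compound 1 and compound 2 each give a limit and not a number: the limit of > 25000 nM in this assay, at which 2 of the 3 values shown sit.

The compounds shown do not tell why the added ring or the ethoxycarbonyl group has these effects. From the compounds shown here alone, whether a methyl group, a fluorine atom or a carboxylic acid could stand on that aromatic carbon and still give a number also remains open.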